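The compounds below may be only part of what the source reports. "The series", "measured", "known", "first", "only" and "open" are said of these compounds alone.

Compound 1 `Cc1ccc(CC(CNC(=O)C(C)(C)c2ccc(NS(C)(=O)=O)cc2)COC(=O)C(C)(C)C)cc1C` and compound 2 `Cc1ccc(CC(CNC(=O)C2(c3ccc(NS(C)(=O)=O)cc3)CC2)COC(=O)C(C)(C)C)cc1C` share one core and differ only in how the two methyl groups on the carbon next to the amide carbonyl are arranged, open-chain in compound 1 and closed into a three-membered ring in compound 2. In an assay on CHO cells for displacement of a labelled ligand from transient receptor potential cation channel subfamily V member 1 (Rattus norvegicus) (a lower number here means a stronger inhibitor, a higher number a weaker inhibitor), compound 1 gives 370 nM, and compound 2 gives 396 nM in this assay. Compound 1 has the lowest of the two numbers, but the gap to compound 2 lies within the usual scatter, so neither can be called the stronger inhibitor.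

Compound 3 `COc1cc(C(C)(C)C(=O)NCC(COC(=O)C(C)(C)C)Cc2ccc(C)c(C)c2)ccc1NS(C)(=O)=O` keeps the open-chain arrangement of compound 1 and changes one position on the aromatic ring carrying the methanesulfonamido group: methoxy in place of hydrogen on an aromatic carbon. Among the measured compounds shown here, no measured pair shows this change, so the expectation rests on the change itself. The step from compound 1 to compound 3 is expected to bring a lower number, a 2.8-fold lower number from compound 1 to compound 3 (0.45 log units; beyond the scatter), a step beyond the scatter. Compound 3 is therefore estimated at 130 nM in this assay, with a range from 40 nM to 400 nM.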

Compound 3, inhibition constant: 153 nM
Compound 3: the middle estimate sits 1.2-fold (0.07 log units) below what was measured; low and high end bracket the measured number.
By their numbers in this assay, from the lowest: compound 3; then compounds 1 and 2 (each within the scatter of the next).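

In this assay, methoxy in place of hydrogen on an aromatic carbon, ortho to a methanesulfonamido group, brings a 2.4-fold lower number from compound 1 to compound 3 (0.38 log units; beyond the scatter) and so gives the first difference in the series that lies beyond the scatter. The open-chain and three-membered ring arrangements of compound 1 and compound 2 had left the numbers within the scatter of each other, so this aromatic position responds where that earlier change did not. Nothing available accounts for the size or direction of this step.

The compounds shown leave open whether a hydroxyl group, a chlorine atom or a longer ethoxy chain at this position would lower the number as methoxy does. They also leave open whether methoxy would bring a similar step on the three-membered ring of compound 2.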